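Dropping the Butyl Chain from Compound 2

The source may hold more compounds than are shown below. What is called first, only, known or untested is meant among the compounds shown, and "the series" means these compounds.

Compound 1, `CCc1ccc2c(=O)c(-c3nn[nH]n3)c[nH]c2c1`: < 5 mg/kg
Compound 2, `CCCCc1ccc2ncc(-c3nn[nH]n3)cc2c1`: 5 mg/kg

Both compounds were tested in a functional assay on the whole organism (strain Sprague-Dawley) for inhibition, with Rattus norvegicus as the target; a higher number here means that more compound is needed for the effect, a lower number that less compound is needed. For compound 1 the value < 5 mg/kg is a limit of the assay, not a number. Compound 1 sits at the limit of < 5 mg/kg in this assay, at which 1 of the 2 values shown sits. Going by the values given here, compound 2 is therefore the only compound with a number in this assay, at 5 mg/kg. Among the compounds with values here, the one further value shown, that of compound 1, is a limit rather than a number. Within the data shown here, no step between two measured compounds can thus be given, and nothing is known about how the two values compare.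

Compound 3, `c1ccc2ncc(-c3nn[nH]n3)cc2c1`, has not been measured. It differs from compound 2 in one place: hydrogen in place of butyl on an aromatic carbon. Among the measured compounds shown here, with only one number in hand, no measured step guides the expectation, and the change is judged on its own. Compound 3 is expected to need somewhat more compound than compound 2, a step of a 2.0-fold higher number from compound 2 to compound 3 (0.30 log units; within the scatter) in this assay. Compound 3 is estimated at 10 mg/kg, within a range from 3 mg/kg to 30 mg/kg.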

Compound 3, minimum effective dose: 10 mg/kg
Compound 3: the middle estimate sits on the measured number at the digits printed, and the stated range covers the measured number.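

Going by these compounds alone, replacing the butyl on this aromatic carbon with hydrogen gives a 2.0-fold higher number from compound 2 to compound 3 (0.30 log units; within the scatter) in this assay, the first step that can be read between two measured compounds. It shows that, in this assay, the whole chain can leave this position without a difference that stands clear of the scatter, so compound 3 retains a measurable effect with hydrogen alone at this carbon. Nothing given here explains why the two compounds read alike.

What the compounds shown leave open is whether this tolerance extends to other kinds of group on the same aromatic carbon, such as an amine, a carboxylic acid or a chain longer than butyl, any of which might move the number beyond the scatter. Also open, as far as these compounds go, is whether hydrogen and butyl would still read alike at the other carbons of this ring, since this single step speaks for one position and one change only.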